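Removing a Methyl from an Aromatic Nitrogen

A few compounds are considered here, and "the series" means these few. Any claim that something is new, unique, unknown or untested is made for them only; others in the source may bear on it.

Of the compounds shown here, three have been measured in an assay for inhibition of MAP kinase-interacting serine/threonine-protein kinase 1 (Homo sapiens), read by luminescence and ADP-Glo, with a stated time of 2 h; on this read-out lower numbers stand for stronger inhibition and higher numbers for weaker inhibition. Compound 1 `CC(=O)Nc1cccc(Cn2cc(-c3ccc4cn[nH]c4c3)ccc2=O)c1` gives 163 nM. Compound 2 `Cn1ncc2ccc(-c3ccc(=O)n(Cc4ccccc4)c3)cc21` reaches only the limit of the assay, > 2000 nM, so no number is known for it. Compound 3 `O=c1ccc(-c2ccc3cc[nH]c3c2)cn1Cc1ccccc1` likewise sits at the assay limit, > 2000 nM. Thus compound 2 stands at the weak end of what is shown, with the limit of > 2000 nM in this assay, at which 2 of the 3 values shown sit, marking where two of the three values rest, while compound 1 alone gives a measured value.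

The step to compound 4 `O=c1ccc(-c2ccc3cn[nH]c3c2)cn1Cc1ccccc1` is hydrogen in place of methyl on an aromatic nitrogen. Among the compounds with values here, no measured pair isolates this change. What can be said is that compound 1, which carries this hydrogen, gives 163 nM. Compound 3, with a different five-membered ring, by contrast stays at the assay limit. Compound 4 is therefore expected to gain inhibition in this assay, with an estimated step of an at least 3.3-fold lower number from compound 2 to compound 4 (0.52 log units; beyond the scatter) beyond the usual scatter. Compound 4 is estimated at 600 nM, within a range of 150 nM to 2500 nM.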

Compound 4, half-maximal inhibitory concentration: 315 nM
Beside the measured number, compound 4's estimate is 1.9-fold (0.28 log units) above it; measured number inside the range.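

In this assay, hydrogen in place of methyl on the aromatic nitrogen now has a direct comparison, with all else unchanged: an at least 6.3-fold lower number from compound 2 to compound 4 (0.80 log units; beyond the scatter). Compound 2 remains a limit and not a number, so this step has a bound rather than an exact size: the limit of > 2000 nM in this assay, at which 2 of the 4 values shown sit. Compound 4 also shows that hydrogen in place of acetamido on an aromatic carbon gives a 1.9-fold higher number from compound 1 to compound 4 (0.29 log units; within the scatter), so this assay does not separate compound 1 from compound 4.

The compounds shown carry only hydrogen or methyl on that aromatic nitrogen, leaving open how an ethyl group or a longer chain there would read. They also leave open how an amine or a carboxylic acid would read in place of acetamido on that aromatic carbon.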